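The source may report more compounds than this note shows. Statements on the series, on what has been measured and on what is new or still open speak of the compounds shown alone.

In an ADME assay on L02 cells (Homo sapiens) for cytotoxicity, read by MTT assay, with a stated time of 24 h (a lower number here means a stronger inhibitor, a higher number a weaker inhibitor), compound 1 `O=C1/C(=C/c2ccncc2)CNC/C1=C\c1ccccc1C(F)(F)F` gives 13400 nM and compound 2 `O=C1/C(=C/c2ccncc2)CN(S(=O)(=O)c2ccc(C(F)(F)F)cc2)C/C1=C\c1ccccc1C(F)(F)F` gives 13800 nM so the two stand level, within the usual scatter of repeated measurements. Neither can be ranked above the other on these numbers.

Compound 3 `O=C1/C(=C/c2ccncc2)CN(S(=O)(=O)c2ccc(F)cc2)C/C1=C\c1ccccc1C(F)(F)F` departs from compound 2 in one place. The change fluoro in place of trifluoromethyl on an aromatic carbon puts fluoro in place of trifluoromethyl on an aromatic carbon, para to a large group, turning a 4-(trifluoromethyl)phenyl into a 4-fluorophenyl.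

Among the measured compounds shown here, no measured pair shows this kind of change directly, so the only anchor is compound 2 at 13800 nM and no step beyond the scatter is expected in this assay for this swap. The estimated change a 1.1-fold lower number from compound 2 to compound 3 (0.03 log units; within the scatter) is therefore small and has no firm direction. For compound 3 the estimated value is 13000 nM with an expected range from 6500 nM to 26000 nM.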

Compound 3, half-maximal inhibitory concentration: 12900 nM
For compound 3 the middle estimate is 1.0-fold (0.00 log units) above the measured one; the range from low to high includes it.
By their numbers in this assay, from the lowest: compounds 3, 1 and 2 (each within the scatter of the next).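

Replacing trifluoromethyl with fluoro at this spot on the aromatic ring gives a 1.1-fold lower number from compound 2 to compound 3 (0.03 log units; within the scatter) in this assay and so these two groups cannot be told apart here. Putting a (4-fluorophenyl)sulfonyl on the amine nitrogen in the ring gives a 1.0-fold lower number from compound 1 to compound 3 (0.02 log units; within the scatter) and so the free amine and this sulfonyl form also stand level. Across these three compounds, neither place has yet moved the number beyond the usual scatter, whether the ring carries one fluorine or a trifluoromethyl and whether the nitrogen carries a hydrogen or a sulfonyl group.

As far as these compounds go, whether an amine or a carboxylic acid on that aromatic ring, or a longer chain on the nitrogen, would shift the number remains open. No measured evidence bears on why these changes leave the number level.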